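Stretching the amide side chain of compound 3

The source may report more compounds than this note shows. Statements on the series, on what has been measured and on what is new or still open speak of the compounds shown alone.

Of the compounds shown here, three have been measured in a functional assay on HT-29 cells (Homo sapiens) for antiproliferative activity, read by sulforhodamine B assay, with a stated time of 48 h; a lower number here means a stronger inhibitor, a higher number a weaker inhibitor. Compound 1 `CCCC(=O)Nc1cccc(S(=O)(=O)Oc2ccccc2C(C)C)c1` gives 13000 nM in this assay, compound 2 `CC(=O)Nc1ccc(S(=O)(=O)Oc2ccccc2C(C)C)cc1` gives 23000 nM, and compound 3 `CCCC(=O)Nc1ccc(S(=O)(=O)Oc2ccccc2I)cc1` gives 11000 nM. Compound 3 holds the lowest of the three numbers; its gap to compound 1 is within the scatter, so no order between them can be read, while its gap to compound 2 is beyond the scatter. Among the measured compounds shown here, none of these pairs differs in only one place, so no single step can be isolated.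

Compound 4 `O=C(NCC1CCCC1)Nc1ccc(S(=O)(=O)Oc2ccccc2I)cc1` has not been measured. It differs from compound 3 in one way: (cyclopentylmethyl)amino in place of propyl on a carbonyl carbon. For the measured compounds named here, no measured pair shows what such a change does, and the three values span only a narrow band of weak inhibition.

The step of a 1.4-fold lower number from compound 3 to compound 4 (0.14 log units; within the scatter) is therefore expected to be small, with no clear direction beyond the scatter. For compound 4 the expected value in this assay is 8000 nM, with a range from 2500 nM to 25000 nM.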

Compound 4, half-maximal inhibitory concentration: 7600 nM
Compound 4: middle estimate off by 1.1-fold (0.02 log units), on the high side; the measured number falls inside the stated range.
By their numbers in this assay, from the lowest: compounds 4, 3, 1 and 2 (each within the scatter of the next, the first and the last beyond it).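

Among the compounds shown here, the first step that changes a single place, a 1.4-fold lower number from compound 3 to compound 4 (0.16 log units; within the scatter) in this assay, shows that this position on the carbonyl carbon accepts a much larger group. The (cyclopentylmethyl)amino group brings a five-membered ring and a hydrogen-bond donor that propyl lacks, yet the two numbers cannot be told apart, so this swap gives no readable effect on antiproliferative activity. No measured evidence accompanies this result to explain it.

The new group differs from propyl in both its ring and its nitrogen, so the compounds shown cannot separate the contribution of either. A butylamino group, which has the nitrogen but no ring, or a cyclopentylmethyl group, which has the ring but no nitrogen, would pull these two features apart.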